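Threonine to methionine side chain with the free acid kept

A few compounds are considered here, and "the series" means these few. Any claim that something is new, unique, unknown or untested is made for them only; others in the source may bear on it.

Compound 1 `C[C@@H](O)[C@H](NC(=O)CN(c1nc(Cl)nc2[nH]cnc12)C1CC1)C(=O)O` is a free acid bearing a 1-hydroxyethyl group. In a functional assay on the whole organism (Tail, strain ICR) with Mus musculus as the target, in the tail flick test, with a stated time of 90 min, at a dose of 25 umol/kg by the oral route (a lower number here means a weaker effect, a higher number a stronger effect of the compound at the dose given), compound 1 gives 35.9%, the highest of the three numbers; compound 3 `C[C@H](NC(=O)CN(c1ncnc2c1ncn2C1CCCCO1)C1CC1)C(=O)OCc1ccccc1` gives 32.1%, which lies within the scatter of that figure, while compound 2 `CC(C)C[C@H](NC(=O)CN(c1nc(Cl)nc2[nH]cnc12)C1CC1)C(=O)OCc1ccccc1` gives 15.2%, a gap beyond the scatter. Compound 4 `CSCC[C@H](NC(=O)CN(c1nc(Cl)nc2[nH]cnc12)C1CC1)C(=O)O` keeps the free acid and the shared core of compound 1 and differs in one place: 2-(methylsulfanyl)ethyl in place of 1-hydroxyethyl on a saturated chain carbon bound to an amide-type nitrogen and a carbonyl carbon. For the measured compounds named here, no measured pair shows the effect of this kind of change, so the expectation rests on the three values alone. Compound 4 is expected to give 30%, with a range from 10% to 50%. The step from a number 5.9 percentage points lower from compound 1 to compound 4 (within the scatter) is thus expected to be small and within the scatter.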

Compound 4, a percentage reported as activity, at one dose (the size of the read-out at that dose, not a potency): 14%
Compound 4: middle estimate off by 16 percentage points, on the high side; the range from low to high includes it.
By their numbers in this assay, from the lowest: compounds 4 and 2 (each within the scatter of the next); then compounds 3 and 1 (each within the scatter of the next).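

The side group at this place on the chain matters even with the free acid and the shared core held fixed: in this assay, 2-(methylsulfanyl)ethyl in place of 1-hydroxyethyl gives a number 21.9 percentage points lower from compound 1 to compound 4 (beyond the scatter) at the dose used. The group that leaves carries a hydrogen-bond donor and the group that enters carries none, yet this single step cannot show whether that difference counts. No measured evidence here explains the change.

Going by these compounds, whether an amine or a plain longer carbon chain at this place would keep the higher number remains open.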